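Aryl substituent changes in a propanoic acid series

The source may report more compounds than this note shows. Statements on the series, on what has been measured and on what is new or still open speak of the compounds shown alone.

Compound 3 `O=C(O)CCc1ccc(NCc2ccccc2)cc1` carries a hydrogen where compound 1 `O=C(O)CCc1ccc(NCc2ccc(C(F)(F)F)cc2)cc1` and compound 2 `Cc1ccc(CNc2ccc(CCC(=O)O)cc2)cc1` carry trifluoromethyl and methyl. In a functional assay on CHO cells for agonist activity at Free fatty acid receptor 1 (Homo sapiens), read by reporter gene assay (a lower number here means a smaller maximal response, a higher number a larger maximal response), compound 1 gives 133%, compound 2 gives 152% and compound 3 gives 144%. Compound 3 therefore stands second highest of the three: the step of a number 8 percentage points lower from compound 2 to compound 3 (within the scatter) is within the scatter, while the step of a number 11 percentage points higher from compound 1 to compound 3 (beyond the scatter) lies beyond it.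

Compound 4 `CN(C)Cc1ccc(CNc2ccc(CCC(=O)O)cc2)cc1` differs from compound 3 by (dimethylamino)methyl in place of hydrogen on an aromatic carbon, on an aromatic carbon para to a large group. For the measured compounds named here, no measured step introduces a (dimethylamino)methyl group, so the only guidance is how tolerant this position has been: a number 19 percentage points higher from compound 1 to compound 2 (beyond the scatter) and a number 11 percentage points higher from compound 1 to compound 3 (beyond the scatter) are modest, and a number 8 percentage points lower from compound 2 to compound 3 (within the scatter) is within the scatter. In this assay a step within the scatter, or at most a modest one, is expected for compound 4, with no clear direction, i.e. a number 1 percentage points higher from compound 3 to compound 4 (within the scatter). Compound 4 is estimated at 145%, with a range from 120% to 170%.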

Compound 4, largest response reached (reported as percent of maximum), in percent of the reference or control that the assay uses: 12%
The estimate for compound 4 lay 133 percentage points above the measured number; measured number outside the range, below it.
By their numbers in this assay, from the lowest: compound 4; then compound 1; then compounds 3 and 2 (each within the scatter of the next).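

The position para to a large group is far less tolerant in this assay than trifluoromethyl, methyl and hydrogen suggested: (dimethylamino)methyl in place of hydrogen gives a large fall (a number 132 percentage points lower from compound 3 to compound 4 (beyond the scatter)), and the fall stays large against the other two substituents (a number 140 percentage points lower from compound 2 to compound 4 (beyond the scatter); a number 121 percentage points lower from compound 1 to compound 4 (beyond the scatter)). Among the earlier compounds, changes here were modest or within the scatter, whereas this single change, with 4 heavy atoms entering (3 carbon, 1 nitrogen), leaves compound 4 with little of the response of the others. Nothing available bears on the cause of this loss.

Going by these compounds, whether the loss goes with the amine nitrogen or with the length of the substituent remains open; a propyl chain or a methoxymethyl group at this position would separate the two. A primary aminomethyl group would show whether the two methyl groups on the nitrogen matter.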